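Removing the amino group from a quinoline alkyne

The source may report more compounds than this note shows. Statements on the series, on what has been measured and on what is new or still open speak of the compounds shown alone.

Compound 2 `Nc1ccnc2cc(C#Cc3c(F)cccc3F)ccc12` stands highest of the two compounds measured: in a functional assay on LS174T cells (Homo sapiens) for inhibition, with a stated time of 4 days, tested at 10 uM (on this read-out lower numbers stand for a weaker effect and higher numbers for a stronger effect at the one concentration tested), compound 2 gives 97.7%, while compound 1 `Fc1cccc(F)c1C#Cc1ccc2c(Cl)ccnc2c1` gives 70.8%. For the measured compounds named here, the only measured step, a number 26.9 percentage points higher from compound 1 to compound 2 (beyond the scatter), shows that the amino group goes with a stronger read-out. Compound 3 `Fc1cccc(F)c1C#Cc1ccc2cccnc2c1` differs from compound 2 by hydrogen in place of amino on an aromatic carbon. Taking the amino group away is expected to reverse that gain, so a drop of similar size is expected, a number 25.7 percentage points lower from compound 2 to compound 3 (beyond the scatter). Compound 3 is therefore expected to give about 72% in this assay, plausibly between 52% and 92%.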

Compound 3, a percentage reported as inhibition, at one concentration (the size of the read-out at that concentration, not a potency): 99.4%
Compound 3: the middle estimate sits 27.4 percentage points below what was measured; the whole stated range lies below it.
By their numbers in this assay, from the lowest: compound 1; then compounds 2 and 3 (each within the scatter of the next).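

In this assay the change from amino to hydrogen at this position gives a number 1.7 percentage points higher from compound 2 to compound 3 (within the scatter), so the amino group is not required for a high read-out in this series. The other step, a number 28.6 percentage points higher from compound 1 to compound 3 (beyond the scatter), shows that chloro alone among these three groups goes with a lower number. Nothing measured here explains either step.

From the compounds shown here alone, whether a methyl or methoxy group at this position would read like hydrogen or like chloro remains open. A single concentration also leaves open whether compound 2 and compound 3 would differ in the size of their effect at any other concentration.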